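Replacing the Triazole with a Methyl Carbamate

The compounds below may be only part of what the source reports. "The series", "measured", "known", "first", "only" and "open" are said of these compounds alone.

Compound 1 `CN(CCC#N)C[C@H]1CN(c2ccc(-n3cc(-c4ccccn4)cn3)c(F)c2)C(=O)O1`: in an ADME assay on L02 cells (Homo sapiens) for cytotoxicity, read by MTT assay, with a stated time of 48 h (a lower number here means a stronger inhibitor, a higher number a weaker inhibitor), compound 1 gives only a limit, > 400 ug/mL.
Compound 2 `O=C1O[C@@H](CN2CCC(O)CC2)CN1c1ccc(-n2cc(-c3ccccn3)cn2)c(F)c1`: in this assay compound 2 gives only a limit, > 400 ug/mL.
Compound 3 `O=C1O[C@@H](Cn2ccnn2)CN1c1ccc(-n2cc(-c3ccccn3)cn2)c(F)c1`: in this assay compound 3 gives 49 ug/mL.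

Compound 3 is thus the only one of the three with a number, the other two sitting at the limit of > 400 ug/mL in this assay, at which 2 of the 3 values shown sit. Compound 4 `COC(=O)NC[C@H]1CN(c2ccc(-n3cc(-c4ccccn4)cn3)c(F)c2)C(=O)O1` differs from compound 3 by (methoxycarbonyl)amino in place of 1H-1,2,3-triazol-1-yl on a saturated chain carbon bound to a saturated ring carbon. The steps that touch this position are an at least 8.1-fold lower number from compound 1 to compound 3 (0.91 log units; beyond the scatter) and an at least 8.1-fold lower number from compound 2 to compound 3 (0.91 log units; beyond the scatter), both replacing an amine with the triazole. Compound 4 carries neither group, so these steps show only that the site matters. Compound 4 is expected to give a higher number than compound 3, by a 3.1-fold higher number from compound 3 to compound 4 (0.49 log units; beyond the scatter). Compound 4 is estimated at 150 ug/mL, in a range from 40 ug/mL to 400 ug/mL.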

Compound 4, half-maximal inhibitory concentration: 71 ug/mL
For compound 4 the middle estimate is 2.1-fold (0.32 log units) above the measured one; the range from low to high includes it.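

In this assay, the open-chain (methoxycarbonyl)amino group and the ring-bearing 1H-1,2,3-triazol-1-yl group stand level on this saturated chain carbon, with a 1.4-fold higher number from compound 3 to compound 4 (0.16 log units; within the scatter), so an aromatic ring at this place is not needed for a number in this range. The gap from the two amines also holds without that ring, with an at least 5.6-fold lower number from compound 2 to compound 4 (0.75 log units; beyond the scatter) and an at least 5.6-fold lower number from compound 1 to compound 4 (0.75 log units; beyond the scatter). Compound 1 and compound 2 remain limits, not numbers: the limit of > 400 ug/mL in this assay, at which 2 of the 4 values shown sit.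

From the compounds shown here alone, whether a primary amine, a carboxylic acid or a longer chain at this place would give a number like those of compound 3 and compound 4 stays open. Going by these compounds, the true size of the steps from compound 1 and compound 2 also stays open.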